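Fluoro to Methyl on the Aryl Ring: Expected Cytotoxicity

The source may hold more compounds than are shown below. What is called first, only, known or untested is meant among the compounds shown, and "the series" means these compounds.

Compound 1 `Cc1cc(=O)n(-c2ccc(F)cc2)nc1C(=O)Nc1ccc(Oc2ncnc3[nH]ccc23)cc1`, compound 2 `Cc1cc(=O)n(-c2cccc(F)c2)nc1C(=O)Nc1ccc(Oc2ncnc3[nH]ccc23)cc1` and compound 3 `Cc1cc(=O)n(-c2ccc(F)cc2)nc1C(=O)Nc1ccc(Oc2ncnc3[nH]ccc23)c(F)c1` share one core and were tested in a functional assay on HepG2 cells (Homo sapiens) for cytotoxicity, read by MTT assay, with a stated time of 72 h; on this read-out higher numbers stand for weaker inhibition and lower numbers for stronger inhibition. For compound 1 the result is a limit of the assay, > 60000 nM. Compound 2 gives 3180 nM and compound 3 gives 12900 nM, so compound 3 carries the higher of the two measured numbers. The step of an at least 18-fold lower number from compound 1 to compound 2 (1.27 log units; beyond the scatter) and the step of an at least 4.6-fold lower number from compound 1 to compound 3 (0.66 log units; beyond the scatter) both start from a compound sitting at the limit (the limit of > 60000 nM in this assay, at which 1 of the 3 values shown sits), so their true size is open. Compound 4 `Cc1ccc(-n2nc(C(=O)Nc3ccc(Oc4ncnc5[nH]ccc45)c(F)c3)c(C)cc2=O)cc1` differs from compound 3 in one place: methyl in place of fluoro on an aromatic carbon. Within the data shown here, no measured step exchanges these two groups, so only a modest shift is expected, namely a 1.3-fold lower number from compound 3 to compound 4 (0.11 log units; within the scatter). Compound 4 is therefore estimated at 10000 nM, between 3000 nM and 40000 nM.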

Compound 4, half-maximal inhibitory concentration: 18800 nM
Compound 4: middle estimate off by 1.9-fold (0.27 log units), on the low side; the range from low to high includes it.
By their numbers in this assay, from the lowest: compound 2; then compounds 3 and 4 (each within the scatter of the next). At a limit, above all of these: compound 1.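

Earlier compounds carried only fluoro or hydrogen on this aromatic carbon, para to a large group. Compound 4 adds a first carbon-based group there, and the exchange gives a 1.5-fold higher number from compound 3 to compound 4 (0.16 log units; within the scatter) in this assay, so in this setting the assay does not tell methyl from fluoro. No measurement shown bears on why the two compounds read alike.

From the compounds shown here alone, whether an amine or a carboxylic acid on this carbon would read like fluoro and methyl stays open. So does whether the same exchange would read alike on the core of compound 1.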